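The source may report more compounds than this note shows. Statements on the series, on what has been measured and on what is new or still open speak of the compounds shown alone.

Of the compounds shown here, two have numbers so far. Compound 1 `O=c1cc(NC2CC2)cc(-c2ccccc2)o1` gives only a limit in a functional assay on KBVIN cells (Homo sapiens) for cytotoxicity, read by MTT assay, with a stated time of 72 h (a higher number here means that more compound is needed for the effect, a lower number that less compound is needed), recorded as > 30 uM, so no single number is known for it. Going by the values given here, compound 2 `CCCCCc1cc(Nc2ccc(OC)cc2)cc(=O)o1` is the only compound with a measured number: in this assay compound 2 gives 4.84 uM. Compound 2 therefore stands as the sole fixed point, while the other value is a limit (the limit of > 30 uM in this assay, at which 1 of the 2 values shown sits).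

Compound 3 `COc1ccc(Nc2cc(-c3ccco3)oc(=O)c2)cc1` is the next step from compound 2. The change is furan-2-yl in place of pentyl on an aromatic carbon, next to the ring oxygen of the shared core. Among the compounds with values here, no step between two measured compounds is available to show how a swap of this kind behaves here, so the expectation rests on the two values alone.

Compound 3 is expected to need somewhat more compound than compound 2, with an expected step of a 2.1-fold higher number from compound 2 to compound 3 (0.32 log units; beyond the scatter), a shift that may reach beyond the usual scatter. On that basis compound 3 is estimated at 10 uM, with a range from 3 uM to 30 uM.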

Compound 3, concentration for half-maximal effect: 1.46 uM
Beside the measured number, compound 3's estimate is 6.8-fold (0.84 log units) above it; the measured number lies below the stated range.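

At the aromatic carbon next to the ring oxygen, the shared core does not depend on a saturated chain: in this assay, furan-2-yl in place of pentyl gives a 3.3-fold lower number from compound 2 to compound 3 (0.52 log units; beyond the scatter) and so takes less compound for the effect, a shift beyond the usual scatter. This position therefore accepts a five-membered aromatic ring with no loss of effect, and the swap keeps the heavy-atom count unchanged while adding a ring and a hydrogen-bond acceptor. Which of these differences accounts for the step cannot be told, and nothing measured among these compounds bears on the reason.

From the compounds shown here alone, a single step gives no trend, so it remains open whether thiophen-2-yl, which carries sulfur where the furan ring carries oxygen, would match furan-2-yl, and whether a shorter chain such as propyl would fall closer to pentyl. Going by these compounds, it is also open whether the same swap would give a similar step if the methoxy group on the other ring were replaced by a hydroxyl or a chlorine atom.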